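Fluorophenyl Swap from Compound 2 to Compound 4

A few compounds are considered here, and "the series" means these few. Any claim that something is new, unique, unknown or untested is made for them only; others in the source may bear on it.

Compound 1 `O=C(Nc1ccc2sc(-c3ccccc3F)nc2c1)N1CCCCC1`, compound 2 `O=C(Nc1ccc2sc(-c3cccc(F)c3)nc2c1)N1CCCC1` and compound 3 `O=C(Nc1ccc2sc(-c3ccccc3)nc2c1)c1cccs1` were tested in an ADME assay on HepG2 cells (Homo sapiens) for inhibition, read by resazurin assay, with a stated time of 48 h; on this read-out lower numbers stand for an effect already at smaller amounts and higher numbers for an effect only at larger amounts of compound. Compound 1 reaches only the limit of the assay, > 50000 nM, and not a number. Compound 2 likewise gives only the limit > 50000 nM in this assay. Compound 3 also stops at the limit > 50000 nM. Compound 2 therefore stands together with the other two at the limit of > 50000 nM in this assay, at which 3 of the 3 values shown sit. Compound 4 `O=C(Nc1ccc2sc(-c3ccc(F)cc3)nc2c1)N1CCCC1` is not yet measured; it differs from compound 2 by 4-fluorophenyl in place of 3-fluorophenyl on an aromatic carbon. For the measured compounds named here, no step between measured compounds is available. The change from compound 2 to compound 4 is expected to bring no step beyond the scatter in this assay, an expected step that the limit leaves unreadable from compound 2 to compound 4. Compound 4 is accordingly estimated at 80000 nM, within 30000 nM to 300000 nM, most likely again only a limit.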

Compound 4, half-maximal effective concentration: > 50000 nM
Compound 4 ended at the assay's limit (the forecaster's own chance of this, stated with the estimate: 90%); the middle value is on the limit's open side.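

For the compounds shown here, no step from compound 2 to compound 4 can be read, as both stop at a limit of the assay: the limit of > 50000 nM in this assay, at which 4 of the 4 values shown sit. The compounds shown leave open whether any change to them would give a readable number in this assay.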